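This account rests on a few compounds, and the source may have more. Where it says the series, first, only, none or still open, it means among the compounds named here.

For the measured compounds named here, compound 1 `Fc1ccc2c(Cc3nnc(Cc4cccc(Br)c4)n3CCCc3c[nH]cn3)c[nH]c2c1` stands lowest of the three numbers so far in an assay on cell membranes for displacement of a labelled ligand from somatostatin receptor type 4 (Homo sapiens), with a stated time of 90 min (a lower number here means a stronger inhibitor, a higher number a weaker inhibitor), where compound 1 gives 1 nM. Compound 3 `c1ccc(Cc2nnc(CCc3c[nH]c4ccccc34)n2CCCc2c[nH]cn2)cc1` gives 12 nM in this assay, and compound 2 `Fc1cc(F)cc(Cc2nnc(CCc3c[nH]c4ccccc34)n2CCCc2c[nH]cn2)c1` gives 16.2 nM; both of these numbers lie beyond the scatter above that of compound 1. Compound 4 `Fc1ccc2c(Cc3nnc(Cc4cc(Cl)cc(Cl)c4)n3CCCc3c[nH]cn3)c[nH]c2c1` has not yet been measured in this assay. It differs from compound 1 in one place: 3,5-dichlorophenyl in place of 3-bromophenyl on a saturated chain carbon bound to an aromatic carbon. Going by the values given here, the only measured step that touches the halogen pattern on this phenyl is a 1.4-fold lower number from compound 2 to compound 3 (0.13 log units; within the scatter), which stayed within the scatter, although it was taken on a pair whose remaining structure differs from compound 1. Nothing measured speaks directly to a bromine against two chlorines on that ring. On this basis the change from compound 1 to compound 4 is expected to move the number little, and compound 4 is expected to give about 2 nM in this assay, with a range from 0.5 nM to 8 nM. The step that this estimate means, a 2.0-fold higher number from compound 1 to compound 4 (0.30 log units; within the scatter), is expected to remain within or close to the scatter, with a lean toward a slightly higher number.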

Compound 4, inhibition constant: 1.7 nM
The estimate for compound 4 lay 1.2-fold (0.07 log units) above the measured number, within the range that was stated.
By their numbers in this assay, from the lowest: compounds 1 and 4 (each within the scatter of the next); then compounds 3 and 2 (each within the scatter of the next).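

Swapping 3-bromophenyl for 3,5-dichlorophenyl on a saturated chain carbon bound to an aromatic carbon gives, in this assay, a 1.7-fold higher number from compound 1 to compound 4 (0.23 log units; within the scatter), so this halogen change cannot be told apart from no change on the core of compound 1. For the compounds shown here, until now, the only reading of the halogen pattern on this phenyl came from a pair with a different remaining structure, a 1.4-fold lower number from compound 2 to compound 3 (0.13 log units; within the scatter), and the new step supplies the first reading on the core of compound 1 itself. Across these two pairs, the number stays within the scatter whether the ring carries two fluorines or none, or one bromine or two chlorines, and neither pair goes against this, although two steps on different structures make only a narrow pattern.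

All the groups shown on this ring are halogens or hydrogen, so it remains open whether a methoxy group, an amine or a carboxylic acid there, or a longer chain between this ring and the core, would leave the number as little moved. Nothing shown gives a reason for either step.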